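A few compounds are considered here, and "the series" means these few. Any claim that something is new, unique, unknown or untested is made for them only; others in the source may bear on it.

Measured so far in an assay on FRT cells for positive allosteric modulation of Cystic fibrosis transmembrane conductance regulator variant N1303K (Homo sapiens), in the presence of a further agent that is not named here; a lower number here means that less compound is needed, a higher number that more compound is needed for the effect:

- compound 1, `COc1ccc2[nH]c3c(c2c1)CCNC31CCN(Cc2ccccc2Cl)CC1`: 2200 nM
- compound 2, `COc1ccc2[nH]c3c(c2c1)CCNC31CCN(Cc2ccc(Br)c(F)c2)CC1`: 1800 nM

For the measured compounds named here, compound 2 stands at the lower end of the two numbers, but its only neighbour is compound 1, and the step of a 1.2-fold lower number from compound 1 to compound 2 (0.09 log units; within the scatter) lies within the scatter. Going by the values given here, that single step, an exchange of one substituted phenyl for another on the benzyl carbon, is the only measured change that bears on the next compound.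

Compound 3, `COc1ccc2[nH]c3c(c2c1)CCNC31CCN(Cc2cc(F)c(F)c(F)c2)CC1`, carries the change (3,4,5-trifluorophenyl in place of 4-bromo-3-fluorophenyl on a saturated chain carbon bound to an amine nitrogen in a ring). It repeats the kind of change seen from compound 1 to compound 2, which produced no movement beyond the scatter. No step beyond the scatter is therefore expected in this assay .

For compound 3 the expected value in this assay is 1900 nM, with a range from 800 nM to 4500 nM. The expected step of a 1.1-fold higher number from compound 2 to compound 3 (0.02 log units; within the scatter) is estimated to lie within the scatter.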

Compound 3, half-maximal effective concentration: 2600 nM
Beside the measured number, compound 3's estimate is 1.4-fold (0.14 log units) below it, within the range that was stated.
By their numbers in this assay, from the lowest: compounds 2, 1 and 3 (each within the scatter of the next).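

In this assay, a third halogen pattern at the position on a saturated chain carbon bound to an amine nitrogen in a ring still gives no separation: the swap to 3,4,5-trifluorophenyl is a 1.4-fold higher number from compound 2 to compound 3 (0.16 log units; within the scatter), and the comparison with the 2-chlorophenyl group is a 1.2-fold higher number from compound 1 to compound 3 (0.07 log units; within the scatter). With fluorine as the only halogen on the ring, compound 3 lies within the scatter of both the bromine-bearing compound 2 and the chlorine-bearing compound 1, so neither bromine nor chlorine is required for a number in this range. No measurement on hand bears on the reason for these numbers.

As far as these compounds go, all three compounds carry a halogen-substituted phenyl here, so it remains open whether a pyridine ring, a carboxylic acid or an amine at this position would move the number beyond the scatter. Also open, from the compounds shown here alone, is whether a change elsewhere, such as a hydroxyl in place of the methoxy group, would do so.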